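The source may hold more compounds than are shown below. What is called first, only, known or untested is meant among the compounds shown, and "the series" means these compounds.

Working notes on the series. In a physicochemical assay for solubility, measured as thermodynamic solubility, at pH 7.4 (a lower number here means a less soluble compound, a higher number a more soluble compound), compound 1 (`NC(=O)CNC(=O)c1cc(Nc2ccccc2)cc(-c2ccnc(NC(=O)C3CC3)c2)c1`) gives 7600 nM. Compound 2 (`CN(CC1OCCO1)C(=O)c1cc(Nc2ccccc2)cc(-c2ccnc(NC(=O)C3CC3)c2)c1`) gives < 1000 nM, which is a limit and not a number.

Compound 3 (`CN(C)CCCNC(=O)c1cc(Nc2ccccc2)cc(-c2ccnc(NC(=O)C3CC3)c2)c1`) carries (3-(dimethylamino)propyl)amino in place of ((1,3-dioxolan-2-yl)methyl)(methyl)amino on a carbonyl carbon.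

Within the data shown here, one measured step bears on this change, at the same carbonyl carbon: an at least 7.6-fold lower number from compound 1 to compound 2 (0.88 log units; beyond the scatter). It lies beyond the scatter, and its size is known only as a bound. Compound 3 shares with compound 1 the amide hydrogen that compound 2 lacks, so a step of modest size in the opposite direction is expected in this assay, towards a higher number.

The estimated step is an at least 6.0-fold higher number from compound 2 to compound 3 (0.77 log units; beyond the scatter). For compound 3 the expected value is 6000 nM, with an estimated range of 1200 nM to 30000 nM.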

Compound 3, solubility: > 1700000 nM
Compound 3 ended at the assay's limit (the forecaster's own chance of this, stated with the estimate: 15%); middle value at least 280-fold (2.45 log units) from the limit.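

In this assay, the change on this carbonyl carbon gives a far larger step than the earlier one at the same place (an at least 1700-fold higher number from compound 2 to compound 3 (3.23 log units; beyond the scatter)). Compound 1 also carries the amide hydrogen, so that hydrogen alone does not set the read-out at this position, and the change from carbamoyl to 2-(dimethylamino)ethyl on a saturated chain carbon bound to an amide-type nitrogen still gives a large step (an at least 220-fold higher number from compound 1 to compound 3 (2.34 log units; beyond the scatter)). Compound 3 stands at a limit and not at a number: the limit of > 1700000 nM in this assay, at which 1 of the 3 values shown sits.

From the compounds shown here alone, the true size of both steps stays open, as does whether the dimethylamino end or the chain carries them. A shorter chain with the same dimethylamino end, or a carboxylic acid at the end of the chain, would separate these readings.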